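This account rests on a few compounds, and the source may have more. Where it says the series, first, only, none or still open, it means among the compounds named here.

Compound 1 `O=C1CSC(c2ccc(O)cc2)N1CCN1CCCCC1`: 10%
Compound 2 `O=C1CSC(c2cccc(F)c2)N1CCN1CCCCC1`: 13%

In an ADME assay on Vero cells (Chlorocebus sabaeus) for cytotoxicity, read by neutral red uptake, tested at 3150 ug/mL (a lower number here means a stronger effect, a higher number a weaker effect of the compound at the concentration tested), compound 1 gives 10%, and compound 2 gives 13%. Among the measured compounds shown here, compound 2 stands at the upper of these two numbers, yet its only neighbour is compound 1, and the step of a number 3 percentage points higher from compound 1 to compound 2 (within the scatter) lies within the scatter, so the two compounds cannot be told apart on this measure. Compound 3 `O=C1CSC(c2ccccc2Cl)N1CCN1CCCCC1` has not yet been measured in this assay. Its difference from compound 2 is 2-chlorophenyl in place of 3-fluorophenyl on a saturated ring carbon. For the measured compounds named here, the one measured step, a number 3 percentage points higher from compound 1 to compound 2 (within the scatter), also swapped one six-membered aromatic ring of carbon only for another on a saturated ring carbon, and the number barely moved. On that basis the step of no change at the digits printed from compound 2 to compound 3 (within the scatter) is expected to stay within the scatter as well. Compound 3 is therefore estimated at 13%, with a range from 3% to 25%.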

Compound 3, a percentage reported as activity, at one concentration (the size of the read-out at that concentration, not a potency): 22%
Estimate against measurement, compound 3: 9 percentage points below; low and high end bracket the measured number.
By their numbers in this assay, from the lowest: compounds 1, 2 and 3 (each within the scatter of the next, the first and the last beyond it).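

In this assay, among the compounds shown here, the group on this saturated ring carbon now gives a first step that can be read: 2-chlorophenyl in place of 4-hydroxyphenyl gives a number 12 percentage points higher from compound 1 to compound 3 (beyond the scatter). By contrast, 2-chlorophenyl in place of 3-fluorophenyl gives a number 9 percentage points higher from compound 2 to compound 3 (within the scatter), so those two groups cannot be told apart here, and only the two ends of the series separate, by a modest amount. Nothing available explains this shift.

The compounds shown do not separate the effect of adding chlorine from that of removing the hydroxyl or of moving the substituent around the aromatic ring. As far as these compounds go, how plain phenyl, or an aromatic ring carrying an amine or a carboxylic acid, would read at this carbon also remains open.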